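A few compounds are considered here, and "the series" means these few. Any claim that something is new, unique, unknown or untested is made for them only; others in the source may bear on it.

Compounds measured in a functional assay on SGC-7901 cells (Homo sapiens) for antiproliferative activity, in the presence of a further agent that is not named here; a higher number here means a weaker inhibitor, a lower number a stronger inhibitor:
- compound 1, `CC(C)(C)OC(=O)N1CCN(CCN[C@@H]2CC[C@@H](c3ccc(Cl)c(Cl)c3)c3ccccc32)CC1`: 17100 nM
- compound 2, `NCCN[C@@H]1CC[C@@H](c2ccc(Cl)c(Cl)c2)c2ccccc21`: 11000 nM
- compound 3, `NCCN[C@@H]1CC[C@H](c2ccc(Cl)c(Cl)c2)c2ccccc21`: 10700 nM

Compound 3 sits at the low end of these three numbers, but neither its gap to compound 2 nor its gap to compound 1 reaches beyond the usual scatter, so the three compounds cannot be told apart in this assay. Among the compounds with values here, the one step that has been measured between neighbours, a 1.0-fold lower number from compound 2 to compound 3 (0.01 log units; within the scatter), rests on the fact that compounds 2 and 3 differ only in the configuration as drawn and therefore says nothing about what a change of substituent might do.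

Compound 4, `NCCCCCCN[C@@H]1CC[C@H](c2ccc(Cl)c(Cl)c2)c2ccccc21`, is the next compound to be examined. It differs from compound 3 in one place: 4-aminobutyl in place of amino on a saturated chain carbon, two bonds along the chain from an amine nitrogen. Within the data shown here, no measured pair shares that kind of change, a lengthening of the chain that carries the terminal amine, so there is no step here from which its effect could be read. Given that the three measured compounds, including compound 1 with its much larger substituent on the same amine nitrogen, all fall within scatter of one another, the account expects compound 4 to stay in the same region, with a 1.1-fold lower number from compound 3 to compound 4 (0.03 log units; within the scatter) amounting to nothing beyond the scatter. The estimate for compound 4 in this assay is 10000 nM, within a range of 4000 nM to 25000 nM.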

Compound 4, half-maximal inhibitory concentration: 18900 nM
Beside the measured number, compound 4's estimate is 1.9-fold (0.28 log units) below it, and the stated range covers the measured number.
By their numbers in this assay, from the lowest: compounds 3, 2, 1 and 4 (each within the scatter of the next).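

In this assay, within the data shown here, the replacement of amino by 4-aminobutyl is the only change of substituent at this position with a step that can be read, and it stays within the scatter: it gives a 1.8-fold higher number from compound 3 to compound 4 (0.25 log units; within the scatter). On a saturated chain carbon, two bonds along the chain from an amine nitrogen, the longer chain therefore leaves compound 4 indistinguishable from compound 3, so this single pair shows no measurable penalty or gain from the added length. Nothing on record speaks to why this step is as small as it is, since the one available fact about the series concerns configuration and not the length of the chain.

Left open is whether a chain ending in a carboxylic acid or a hydroxyl rather than an amine, or a chain longer than 4-aminobutyl, would move the number beyond the scatter. Among these compounds, it also remains open whether configuration matters once the chain is longer, as the only reading of it, a 1.0-fold lower number from compound 2 to compound 3 (0.01 log units; within the scatter), comes from the short chain.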